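Swapping the Side Group of Compound 2 for Carboxy

A few compounds are considered here, and "the series" means these few. Any claim that something is new, unique, unknown or untested is made for them only; others in the source may bear on it.

Values in an ADME assay on HEp-2 cells (Homo sapiens) for cytotoxicity; on this read-out lower numbers stand for higher toxicity in this test and higher numbers for lower toxicity in this test:
- Compound 1 `CC(C)CCn1c(Cn2c(=O)n(C(C)C)c3ccccc32)nc2ccc(CN)cc21`: 28100 nM
- Compound 2 `CC(C)CCn1c(Cn2c(=O)n(C(C)C)c3ccccc32)nc2ccc(CN(C)C)cc21`: 26700 nM

Compound 2 stands at 26700 nM, level with compound 1. Compound 3 `CC(C)CCn1c(Cn2c(=O)n(C(C)C)c3ccccc32)nc2ccc(C(=O)O)cc21` carries carboxy in place of (dimethylamino)methyl on an aromatic carbon. Within the data shown here, the only measured step that bears on this is a 1.1-fold lower number from compound 1 to compound 2 (0.02 log units; within the scatter). Among the measured compounds shown here, that step altered only the groups on the nitrogen, and no measured compound carries carboxy, so it is a weak guide. In this assay, a modest move to a higher number is expected, a 1.7-fold higher number from compound 2 to compound 3 (0.23 log units; within the scatter). For compound 3 the estimated value is 45000 nM, with an expected range of 18000 nM to 110000 nM.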

Compound 3, half-maximal cytotoxic concentration: 125000 nM
Beside the measured number, compound 3's estimate is 2.8-fold (0.44 log units) below it; the whole stated range lies below it.
By their numbers in this assay, from the lowest: compounds 2 and 1 (each within the scatter of the next); then compound 3.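

At this aromatic carbon, the choice of group does move the number in this assay: carboxy gives (in place of (dimethylamino)methyl) a 4.7-fold higher number from compound 2 to compound 3 (0.67 log units; beyond the scatter) and (in place of aminomethyl) a 4.4-fold higher number from compound 1 to compound 3 (0.65 log units; beyond the scatter). Among these compounds, the change between the two amines on this carbon had stayed within the scatter, so this is the first step here to go beyond it, towards lower toxicity in this test. Nothing measured here explains the shift. On these data alone, whether the higher number needs carboxy itself, or would also come with a methyl ester or a primary amide on the same aromatic carbon, stays open.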